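The source may report more compounds than this note shows. Statements on the series, on what has been measured and on what is new or still open speak of the compounds shown alone.

Working notes on the series in an ADME assay on L02 cells (Homo sapiens) for cytotoxicity, read by MTT assay, with a stated time of 72 h; on this read-out higher numbers stand for weaker inhibition and lower numbers for stronger inhibition. Compound 2 `CCC/C=C/C(=O)Nc1cccc(Oc2nc(Nc3ccn(C)n3)nc3c2CSCC3)c1` stands at > 50000 nM, which is a limit and not a number. Compound 1 `CC/C=C/C(=O)Nc1cccc(Oc2nc(Nc3ccn(C)n3)nc3c2CSCC3)c1` gives > 50000 nM, also a limit. Compound 3 `CC(C)=CC(=O)Nc1cccc(Oc2nc(Nc3ccn(C)n3)nc3c2CSCC3)c1` gives > 50000 nM, again a limit. All three share (the limit of > 50000 nM in this assay, at which 3 of the 3 values shown sit). The steps a step that the two limits leave unreadable from compound 1 to compound 2, a step that the two limits leave unreadable from compound 1 to compound 3 and a step that the two limits leave unreadable from compound 2 to compound 3 therefore offer no readable size. Compound 4 `C=C(F)C(=O)Nc1cccc(Oc2nc(Nc3ccn(C)n3)nc3c2CSCC3)c1` differs from compound 2 by 1-fluoroethenyl in place of pent-1-en-1-yl on a carbonyl carbon. Among the measured compounds shown here, no measured step covers this change. The step of an at least 1.2-fold lower number from compound 2 to compound 4 (0.09 log units; that floor lies within the scatter) is expected to be small, toward stronger inhibition if readable at all. Compound 4 is estimated at 40000 nM, with an expected range of 12000 nM to 50000 nM.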

Compound 4, half-maximal inhibitory concentration: 47800 nM
For compound 4 the middle estimate is 1.2-fold (0.08 log units) below the measured one; the measured number falls inside the stated range.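

In this assay compound 4 is the only compound shown that gives a number and not a limit, so 1-fluoroethenyl on this carbonyl carbon brings the read-out into measurable range. The other compounds offer no number for comparison: the limit of > 50000 nM in this assay, at which 3 of the 4 values shown sit. The readable floors are an at least 1.0-fold lower number from compound 2 to compound 4 (0.01 log units; that floor lies within the scatter), an at least 1.0-fold lower number from compound 3 to compound 4 (0.01 log units; that floor lies within the scatter) and an at least 1.0-fold lower number from compound 1 to compound 4 (0.01 log units; that floor lies within the scatter), so 1-fluoroethenyl cannot be ranked against pent-1-en-1-yl, 2-methylprop-1-en-1-yl or but-1-en-1-yl. Still open, going by these compounds, is whether any group on this carbonyl carbon, such as unsubstituted ethenyl or a longer chain carrying an amine, gives a step beyond the scatter.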